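From dimethylamino to propylamino at the limit of tolerance

The compounds below may be only part of what the source reports. "The series", "measured", "known", "first", "only" and "open" are said of these compounds alone.

In an ADME assay on CCRF-HSB-2 cells (Homo sapiens) for cytotoxicity, with a stated time of 7 days (a higher number here means that more compound is tolerated, a lower number that less compound is tolerated), compound 1 `CN(C)c1nc(N)nc2c1ncn2/C=C1/CC1(CO)CO` gives > 20000 nM as a limit and not as a number. Compound 2 `Nc1nc(NC2CC2)c2ncn(/C=C3/CC3(CO)CO)c2n1` gives > 20000 nM as a limit too. Compound 3 `Nc1nc2c(ncn2/C=C2/CC2(CO)CO)c(=O)[nH]1` gives > 20000 nM as a limit as well. Compound 1 thus stands with the other two at the limit of > 20000 nM in this assay, at which 3 of the 3 values shown sit, and none of the three has a true number.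

Compound 4 `CCCNc1nc(N)nc2c1ncn2/C=C1/CC1(CO)CO` has not yet been measured. The change propylamino in place of dimethylamino on an aromatic carbon puts propylamino in place of dimethylamino on an aromatic carbon of the shared core, and no ring enters with it.

Going by the values given here, the one measured step that bears on this is a step that the two limits leave unreadable from compound 1 to compound 2 where cyclopropylamino takes the place of dimethylamino on the same aromatic carbon. That step offers no size to carry over. Compound 2 still reads > 20000 nM as a limit, so no step beyond the scatter is expected in this assay and another limit is the likely outcome. The estimated move is a number no higher from compound 1 to compound 4 (the limit leaves the size open) and no direction is expected for it. For compound 4 the estimated value is 20000 nM with an expected range from 10000 nM to 40000 nM around it.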

Compound 4, half-maximal cytotoxic concentration: > 20000 nM
Compound 4 gave a limit, no number (the forecaster's own chance of this, stated with the estimate: 80%); the middle value sits exactly at the limit.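

In this assay no step from compound 1 or compound 2 to compound 4 can be read, since compound 4 joins the others at a limit and not a number: the limit of > 20000 nM in this assay, at which 4 of the 4 values shown sit.

The compounds shown leave open how far apart their true values lie, and whether any change at this place on the shared core would give a true number in this assay.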